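Bromo compounds: replacing hydroxy with amino

The source may hold more compounds than are shown below. What is called first, only, known or untested is meant among the compounds shown, and "the series" means these compounds.

Compound 1 `Cn1c(/C=C/C(=O)c2ccccc2)cc(Br)c1Br`: >= 100000 nM, a limit
Compound 2 `Cn1c(/C=C/C(=O)c2cccc(O)c2)cc(Br)c1Br`: >= 100000 nM, a limit
Compound 3 `Cn1c(/C=C/C(=O)c2cc(O)ccc2O)cc(Br)c1Br`: 880 nM
Compound 4 `Cn1c(/C=C/C(=O)c2cccc(N)c2)cc(Br)c1Br`: not yet measured

In a functional assay on WRL68 cells (Homo sapiens) for cytotoxicity, read by MTT assay, with stated times of 6 h and 48 h (on this read-out higher numbers stand for weaker inhibition and lower numbers for stronger inhibition), compound 2 stands only at a limit, >= 100000 nM. This is the limit of >= 100000 nM in this assay, at which 2 of the 3 values shown sit. Compound 4 differs from compound 2 by one change: amino in place of hydroxy on an aromatic carbon. Among the compounds with values here, two measured steps bear on it, each placing hydroxy in place of hydrogen on an aromatic carbon. Within the data shown here, the first is a step that the two limits leave unreadable from compound 1 to compound 2. The second, a large one, is an at least 110-fold lower number from compound 2 to compound 3 (2.05 log units; beyond the scatter). Compound 3, at 880 nM, carries a further hydroxy that compound 4 lacks, so no comparably large fall is expected. The expected change is an at least 1.4-fold lower number from compound 2 to compound 4 (0.15 log units; that floor lies within the scatter), and it may not exceed the scatter. Compound 4 is estimated at 70000 nM, with an expected range of 10000 nM to 100000 nM.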

Compound 4, half-maximal inhibitory concentration: >= 100000 nM
Compound 4 ended at the assay's limit (the forecaster's own chance of this, stated with the estimate: 60%); middle value at least 1.4-fold (0.15 log units) from the limit.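

Compound 4 stands at a limit in this assay, as do compound 1 and compound 2, so neither step to compound 4 can be read: the limit of >= 100000 nM in this assay, at which 3 of the 4 values shown sit. The compounds shown leave open whether amino in place of hydroxy changes the read-out at all.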